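A few compounds are considered here, and "the series" means these few. Any claim that something is new, unique, unknown or untested is made for them only; others in the source may bear on it.

Measured so far in a functional assay (muscle tissue) with Rattus norvegicus as the target; on this read-out lower numbers stand for an effect already at smaller amounts and higher numbers for an effect only at larger amounts of compound:
compound 1 `CCCCNC(=O)C1=CC(C)(C)Oc2ccc([N+](=O)[O-])cc21`: 21.9 nM
compound 2 `CC(C)NC(=O)C1=CC(C)(C)Oc2ccc([N+](=O)[O-])cc21`: 186 nM
compound 3 `CC1(C)C=C(C(=O)NCC2CC2)c2cc([N+](=O)[O-])ccc2O1`: 6.61 nM

Compound 3 gives the lowest number of the three. The steps of a 3.3-fold lower number from compound 1 to compound 3 (0.52 log units; beyond the scatter) and a 28-fold lower number from compound 2 to compound 3 (1.45 log units; beyond the scatter) both lie beyond the scatter, so compound 3 is set apart from both other compounds; compound 1 is the nearer of the two, compound 2 the further.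

Compound 4 `CC1(C)C=C(C(=O)NCCC#N)c2cc([N+](=O)[O-])ccc2O1` has not yet been measured. The change from compound 3 is cyanomethyl in place of cyclopropyl on a saturated chain carbon bound to an amide-type nitrogen. The cyclopropyl leaves and a cyanomethyl enters, so the three-membered non-aromatic ring of carbon only is gone, and in its place stands a chain with a triple bond outside aromatic rings and one hydrogen-bond acceptor, on the saturated chain carbon bound to the amide-type nitrogen.

Going by the values given here, only one measured step touches this place: a 3.3-fold lower number from compound 1 to compound 3 (0.52 log units; beyond the scatter), where cyclopropyl replaced propyl. The other two, an 8.5-fold higher number from compound 1 to compound 2 (0.93 log units; beyond the scatter) and a 28-fold lower number from compound 2 to compound 3 (1.45 log units; beyond the scatter), alter the group on the amide-type nitrogen itself, and show that this assay answers to such changes with modest to large steps. Because the ring gained in a 3.3-fold lower number from compound 1 to compound 3 (0.52 log units; beyond the scatter) is now lost again, a step toward a higher number is expected, roughly a 3.8-fold higher number from compound 3 to compound 4 (0.58 log units; beyond the scatter). Among the compounds with values here, no measured step brings in a nitrile, so the range is kept wide. For compound 4 the expected value is 25 nM, between 8 nM and 80 nM.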

Compound 4, half-maximal effective concentration: 2.82 nM
Estimate against measurement, compound 4: 8.9-fold (0.95 log units) above; measured number below the stated range.
By their numbers in this assay, from the lowest: compound 4; then compound 3; then compound 1; then compound 2.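

In this assay the three-membered ring at this place, on a saturated chain carbon bound to an amide-type nitrogen, proves dispensable: an open cyanomethyl in its place moves the number further down rather than back up (a 2.3-fold lower number from compound 3 to compound 4 (0.37 log units; beyond the scatter)), so the earlier gain of cyclopropyl over propyl does not mean that this position requires a ring. Against the butyl chain of compound 1, cyano in place of ethyl gives a larger step (a 7.8-fold lower number from compound 1 to compound 4 (0.89 log units; beyond the scatter)), and the distance from the isopropyl amide grows as well (a 66-fold lower number from compound 2 to compound 4 (1.82 log units; beyond the scatter)), which leaves compound 4 the lowest of the four, with every step to it beyond the scatter. Nothing available explains why the nitrile chain gives the lowest number.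

Still open, going by these compounds, is whether the nitrile itself matters or only the open chain that carries it, which a longer chain ending in a nitrile, or a chain ending in an amine or a carboxylic acid, would help to separate. On these data alone, all four compounds share one core, so whether this order of amide groups holds on another core also remains unknown.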